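The compounds below may be only part of what the source reports. "The series", "measured", "known", "first", "only" and "open" are said of these compounds alone.

Compound 1 `CCOC(=O)c1nn(-c2ccccc2)/c(=N/c2nc(-c3c(C)n(C)n(-c4ccccc4)c3=O)cs2)s1` was tested in a functional assay on MCF7 cells (Homo sapiens) for cytotoxicity, read by sulforhodamine B assay, with a stated time of 72 h (on this read-out higher numbers stand for weaker inhibition and lower numbers for stronger inhibition), and gives a value that is only a limit of the assay, > 100000 nM. Compound 2 `CCOC(=O)c1nn(-c2ccc(Cl)cc2)/c(=N/c2nc(-c3c(C)n(C)n(-c4ccccc4)c3=O)cs2)s1` differs from compound 1 as follows (chloro in place of hydrogen on an aromatic carbon). In this assay compound 2 likewise gives only a limit, > 100000 nM. The step that the two limits leave unreadable from compound 1 to compound 2 therefore cannot be read, because of the limit of > 100000 nM in this assay, at which 3 of the 3 values shown sit. Compound 3 `Cc1c(-c2csc(/N=C3\S/C(=C\c4ccccc4)C(=O)N3c3ccccc3)n2)c(=O)n(-c2ccccc2)n1C` carries a different core; how the two cores differ is not broken down here. In this assay compound 3 also gives only a limit, > 100000 nM. Compound 4 `Cc1c(-c2csc(/N=C3\S/C(=C\c4ccc(Cl)cc4)C(=O)N3c3ccccc3)n2)c(=O)n(-c2ccccc2)n1C` differs from compound 3 by the same change, (chloro in place of hydrogen on an aromatic carbon). Since compound 1 and compound 2 sit at the limit on either side of that change, compound 4 is expected to stay at the limit as well, with an estimated step that the limit leaves unreadable from compound 3 to compound 4. The estimate for compound 4 is 150000 nM, between 50000 nM and 600000 nM.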

Compound 4, half-maximal inhibitory concentration: > 100000 nM
Compound 4 ended at the assay's limit (the forecaster's own chance of this, stated with the estimate: 85%); the middle value does not contradict the limit.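

Among the compounds shown here, compound 3 and compound 4 both stand at a limit of the assay, so no step between them can be read: the limit of > 100000 nM in this assay, at which 4 of the 4 values shown sit. The compounds shown leave open whether chloro in place of hydrogen changes the read-out at all.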